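The compounds below may be only part of what the source reports. "The series", "measured", "known", "first", "only" and "open" are said of these compounds alone.

The shared core carries an amide; compound 1 `Cc1cnc(C(=O)Nc2cc(Cl)cc3cccnc23)cn1` bears a 5-methylpyrazin-2-yl on the carbonyl carbon, compound 2 `O=C(Nc1cc(Cl)cc2cccnc12)c1cnccn1` a pyrazin-2-yl, and compound 3 `O=C(Nc1cc(Cl)cc2cccnc12)c1ncccn1` a pyrimidin-2-yl. In a functional assay on BXPC-3 cells (Homo sapiens) for inhibition, read by MTT assay, with a stated time of 72 h (on this read-out lower numbers stand for stronger inhibition and higher numbers for weaker inhibition), compound 1 gives 5200 nM. For compound 2 the read-out is only a limit of the assay, > 10000 nM. For compound 3 it is likewise a limit, > 10000 nM. Compound 2 stands where (the limit of > 10000 nM in this assay, at which 2 of the 3 values shown sit), and the step from compound 1 is only a floor that stays within the scatter. The steps found so far, an at least 1.9-fold higher number from compound 1 to compound 2 (0.28 log units; that floor lies within the scatter) and an at least 1.9-fold higher number from compound 1 to compound 3 (0.28 log units; that floor lies within the scatter), both alter the group on the carbonyl carbon, while a step that the two limits leave unreadable from compound 2 to compound 3 cannot be read. Compound 4 `O=C(Nc1cc(OCCF)cc2cccnc12)c1cnccn1` changes a different part: 2-fluoroethoxy in place of chloro on an aromatic carbon. Going by the values given here, no measured step touches that position, and nothing in these numbers sets a direction or size for it. Starting from compound 2, the estimated step is a step that the limit leaves unreadable from compound 2 to compound 4, resting on the standing of compound 2 alone. Compound 4 is expected to give about 12000 nM, within 3000 nM to 40000 nM, most likely again only a limit.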

Compound 4, half-maximal inhibitory concentration: 4330 nM
Estimate against measurement, compound 4: 2.8-fold (0.44 log units) above; measured number inside the range.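

Going by these compounds alone, the earlier compounds differ only in the group on the carbonyl carbon, so compound 4 gives the first view of a change on the six-membered aromatic ring of carbon only. In this assay, 2-fluoroethoxy in place of chloro gives an at least 2.3-fold lower number from compound 2 to compound 4 (0.36 log units; beyond the scatter), which shows that this position can shift the read-out and that a chain of 4 heavy atoms is accepted there. That size is only a floor, since compound 2 sits at a limit of the assay and not at a number: the limit of > 10000 nM in this assay, at which 2 of the 4 values shown sit.

As far as these compounds go, how a methoxy group, a longer chain or an amine would read at this position stays open, so the part played by the fluorine cannot be separated from that of the chain. Also open, from the compounds shown here alone, is whether the same change would carry over with 5-methylpyrazin-2-yl or pyrimidin-2-yl on the carbonyl carbon.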